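Extending the allyl side chain of a tetrahydropyran diol scaffold

A few compounds are considered here, and "the series" means these few. Any claim that something is new, unique, unknown or untested is made for them only; others in the source may bear on it.

The series was read in a functional assay on HL-60 cells (Homo sapiens) for cytotoxicity, read by WST assay, with a stated time of 48 h; on this read-out higher numbers stand for weaker inhibition and lower numbers for stronger inhibition. Compound 1 `C=CC[C@H]1C[C@@H]([C@@H](O)c2ccccc2)CO[C@@H]1c1ccccc1` gives 36000 nM in this assay, the highest of the two numbers obtained so far. Compound 3 `COc1ccc(/C=C/C[C@@H]2C[C@@H]([C@@H](O)c3ccc(OC)c(OC)c3)CO[C@H]2c2ccc(OC)c(OC)c2)cc1OC` gives 26000 nM in this assay, and the gap between these two values lies within the usual scatter, so neither compound can be placed ahead of the other. Compound 2 `COc1ccc(/C=C/C[C@@H]2C[C@H]([C@H](O)c3ccc(OC)c(OC)c3)CO[C@H]2c2ccc(OC)c(OC)c2)cc1OC` returned "not determined" (no result reported) in this assay; the fact that compounds 2 and 3 differ only in the configuration as drawn is the only thing that separates it from compound 3.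

The unmeasured compound 4 `O[C@@H](c1ccccc1)[C@H]1CO[C@H](c2ccccc2)[C@@H](C/C=C/c2cccnc2)C1` differs from compound 1 by a single change: 2-(pyridin-3-yl)ethenyl in place of vinyl on a saturated chain carbon bound to a saturated ring carbon. Among the compounds with values here, no measured pair in this set walks the same step, so the direction must be guessed. Compound 4 is expected to show an improvement, with the step from compound 1 to compound 4 estimated at a 1.8-fold lower number from compound 1 to compound 4 (0.26 log units; within the scatter), though the size is uncertain and could still fall within the scatter. For compound 4 the estimate in this assay is 20000 nM, within a range from 6000 nM to 60000 nM.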

Compound 4, half-maximal inhibitory concentration: > 100000 nM
Compound 4: no number, only a limit; the forecaster's own chance of this, stated with the estimate: 15%; middle value at least 5.0-fold (0.69 log units) away from the limit.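

In this assay, replacing vinyl with 2-(pyridin-3-yl)ethenyl on a saturated chain carbon bound to a saturated ring carbon gives an at least 2.7-fold higher number from compound 1 to compound 4 (0.44 log units; beyond the scatter), so on the core of compound 1 this change weakens inhibition. For compound 4 the reading is a limit of the assay and not a number: the limit of > 100000 nM in this assay, at which 1 of the 4 values shown sits. The earlier compounds shown here did not show this, as compound 1 and compound 3 differ in more than one place and no step among them could be read.

From the compounds shown here alone, it remains open whether this step follows the ring nitrogen or the larger group as a whole; a 2-phenylethenyl group in the same place on the core of compound 1 would separate the two. Going by these compounds, it is also open whether the same change would act alike on the methoxy-bearing core of compound 3.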